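Furan-to-thiophene swap on a longer chain

The source may hold more compounds than are shown below. What is called first, only, known or untested is meant among the compounds shown, and "the series" means these compounds.

Measured compounds:
compound 1, `CCCCCCCCCCCCCCNC(=O)[C@@H](NC(=O)c1ccco1)[C@@H](C)O`, 190000 nM
compound 2, `CCCCCCCCCCCCCCNC(=O)[C@@H](NC(=O)c1cccs1)[C@@H](C)O`, 26500 nM
compound 3, `CCCCCCCCCCCCCCCCCCNC(=O)[C@@H](NC(=O)c1ccco1)[C@@H](C)O`, 19900 nM

In a functional assay on A-431 cells (Homo sapiens) for cytotoxicity, read by MTT assay, with a stated time of 48 h (a lower number here means a stronger inhibitor, a higher number a weaker inhibitor), compound 1 gives 190000 nM. Two single changes start from it. The first, (thiophen-2-yl in place of furan-2-yl on a carbonyl carbon), brings a 7.2-fold lower number from compound 1 to compound 2 (0.86 log units; beyond the scatter). The second, (butyl in place of hydrogen on a saturated chain carbon, ten or more bonds along the chain from an amide-type nitrogen), brings a 9.5-fold lower number from compound 1 to compound 3 (0.98 log units; beyond the scatter). Compound 3 and compound 2 lie within the scatter of each other, so no order between them is claimed.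

Compound 4, `CCCCCCCCCCCCCCCCCCNC(=O)[C@@H](NC(=O)c1cccs1)[C@@H](C)O`, has not yet been measured in this assay. It stands to compound 3 as compound 2 stands to compound 1: the change is thiophen-2-yl in place of furan-2-yl on a carbonyl carbon, and the two cores differ by butyl in place of hydrogen on a saturated chain carbon, ten or more bonds along the chain from an amide-type nitrogen, the place of the swap being the same in both pairs. Among the measured compounds shown here, the one earlier instance of this change is the step of a 7.2-fold lower number from compound 1 to compound 2 (0.86 log units; beyond the scatter). For the measured compounds named here, a step of similar size is expected here, a 5.0-fold lower number from compound 3 to compound 4 (0.70 log units; beyond the scatter), resting on that single precedent and on the value of compound 3, 19900 nM, though with only one example the size is uncertain. Compound 4 is therefore estimated at 4000 nM, within 1500 nM to 12000 nM.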

Compound 4, half-maximal inhibitory concentration: 33300 nM
Beside the measured number, compound 4's estimate is 8.3-fold (0.92 log units) below it; measured number outside the range, above it.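

In this assay, thiophen-2-yl in place of furan-2-yl on the longer chain gives a 1.7-fold higher number from compound 3 to compound 4 (0.22 log units; within the scatter), so the step seen on the shorter chain does not carry over to this core: the same change on two cores in this assay, a 7.2-fold lower number (0.86 log units; beyond the scatter) from compound 1 to compound 2 and a 1.7-fold higher number (0.22 log units; within the scatter) from compound 3 to compound 4, 12-fold (1.08 log units) apart, beyond the scatter of two such steps. Adding butyl to the chain likewise behaves differently once thiophen-2-yl is present, giving a 1.3-fold higher number from compound 2 to compound 4 (0.10 log units; within the scatter): the same change on two cores in this assay, a 9.5-fold lower number (0.98 log units; beyond the scatter) from compound 1 to compound 3 and a 1.3-fold higher number (0.10 log units; within the scatter) from compound 2 to compound 4, 12-fold (1.08 log units) apart, beyond the scatter of two such steps. Among the compounds shown here, this shows that, in these four compounds, neither change has a size that can be transferred from one core to the other, but with only two cores it does not show how the swap behaves across the series or what underlies the difference.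

The compounds shown leave open whether the step on a shorter or a still longer chain would resemble that from compound 1 or that from compound 3. They also leave open how a phenyl or pyridin-2-yl group on the carbonyl carbon would behave on either chain.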